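Pyridin-4-yl to 4-(trifluoromethyl)phenyl: compound 1 to compound 4

A few compounds are considered here, and "the series" means these few. Any claim that something is new, unique, unknown or untested is made for them only; others in the source may bear on it.

Measured in a functional assay on MCF7 cells (Homo sapiens) for antiproliferative activity, read by MTT assay, with a stated time of 72 h; a lower number here means a stronger inhibitor, a higher number a weaker inhibitor:
- compound 1 `CC1=CC[C@H]2[C@H](CC[C@]2(C)O)C(C)(C)[C@@H]1CC[C@H]1[C@]2(C)CC[C@H](OC(=O)c3ccncc3)C(C)(C)O[C@H]2CC[C@@]1(C)O` gives 25300 nM
- compound 2 `CC1=CC[C@H]2[C@@H]1CC=C(C)[C@@H](CC[C@H]1[C@]3(C)CC[C@H](OC(=O)c4ccncc4)C(C)(C)O[C@H]3CC[C@@]1(C)O)C2(C)C` gives > 50000 nM, which is a limit of the assay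
- compound 3 `CC1=CC[C@H]2[C@@H]1CC=C(C)[C@@H](CC[C@H]1[C@]3(C)CC[C@H](OC(=O)c4ccc(Cl)cc4)C(C)(C)O[C@H]3CC[C@@]1(C)O)C2(C)C` gives 22000 nM

Compound 3 at 22000 nM and compound 1 at 25300 nM lie within the usual scatter of each other. Compound 2 gives no number, only the limit > 50000 nM.

Compound 4 `CC1=CC[C@H]2[C@H](CC[C@]2(C)O)C(C)(C)[C@@H]1CC[C@H]1[C@]2(C)CC[C@H](OC(=O)c3ccc(C(F)(F)F)cc3)C(C)(C)O[C@H]2CC[C@@]1(C)O` keeps the core of compound 1 and differs from it as follows: 4-(trifluoromethyl)phenyl in place of pyridin-4-yl on a carbonyl carbon. In words, this is 4-(trifluoromethyl)phenyl in place of pyridin-4-yl on a carbonyl carbon.

Among the measured compounds shown here, one measured step bears on this change: an at least 2.2-fold lower number from compound 2 to compound 3 (0.35 log units; beyond the scatter). It replaces the same pyridin-4-yl, but with 4-chlorophenyl and on the core of compound 2, so it transfers only loosely. Its direction is taken over, with a similar modest size expected.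

In this assay the expected shift is towards a lower number, estimated as a 2.5-fold lower number from compound 1 to compound 4 (0.40 log units; beyond the scatter).

For compound 4 the expected value is 10000 nM, with an estimated range from 4000 nM to 25000 nM.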

Compound 4, half-maximal inhibitory concentration: 23400 nM
For compound 4 the middle estimate is 2.3-fold (0.37 log units) below the measured one; the measured number falls inside the stated range.
By their numbers in this assay, from the lowest: compounds 3, 4 and 1 (each within the scatter of the next). At a limit, above all of these: compound 2.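

With pyridin-4-yl replaced by 4-(trifluoromethyl)phenyl on the carbonyl carbon, this assay gives a 1.1-fold lower number from compound 1 to compound 4 (0.03 log units; within the scatter). On the core of compound 1, these two groups therefore cannot be told apart at this position, and the earlier step on the core of compound 2, an at least 2.2-fold lower number from compound 2 to compound 3 (0.35 log units; beyond the scatter), does not carry over to this change. That earlier step has only a bound for its size, as compound 2 stands at a limit of the assay: the limit of > 50000 nM in this assay, at which 1 of the 4 values shown sits.

Open, as far as these compounds go, is whether the two cores respond differently to the same group on the carbonyl carbon, which needs one group carried on both cores. A longer alkyl chain, an amine or a carboxylic acid on that carbon would show whether an aromatic ring is needed there at all.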